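The compounds below may be only part of what the source reports. "The series", "measured", "known", "first", "only" and "open" are said of these compounds alone.

Going by the values given here, compound 3 `Cc1cc(O)cc(-c2nn(CC#N)cc2-c2ccnc(-c3ccc(Oc4ccccc4)cc3)c2)c1` is one of three compounds measured in a functional assay on MCF7 cells (Homo sapiens) for cytotoxicity, read by sulforhodamine B assay, with a stated time of 48 h, tested at 0.001 uM; a lower number here means a stronger effect, a higher number a weaker effect of the compound at the concentration tested. In this assay compound 3 gives 92%, a number that lies within the usual scatter of compound 2 `COc1cc(C)cc(-c2nn(CC#N)cc2-c2ccc(-c3cccc(C(C)=O)c3)nc2)c1` at 94% and of compound 1 `COc1cc(C)cc(-c2c(-c3ccnc(-c4ccc(C(C)=O)cc4)c3)cnn2CC#N)c1` at 96%, so the three cannot be told apart on these numbers. Compound 4 `Cc1cc(O)cc(-c2nn(CC#N)cc2-c2ccnc(-c3ccc(N(C)C)cc3)c2)c1` has not yet been measured. Its structure differs from that of compound 3 in one place: dimethylamino in place of phenoxy on an aromatic carbon. Among the compounds with values here, no measured pair here shows a change of this kind, so nothing in the numbers points to a step in either direction. Compound 4 is therefore expected to give about 90% in this assay, with a plausible range from 75% to 99%, the estimated step of a number 2 percentage points lower from compound 3 to compound 4 (within the scatter) being expected to fall within the scatter.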

Compound 4, a percentage reported as activity, at one concentration (the size of the read-out at that concentration, not a potency): 97%
For compound 4 the middle estimate is 7 percentage points below the measured one, and the stated range covers the measured number.
By their numbers in this assay, from the lowest: compounds 3, 2, 1 and 4 (each within the scatter of the next).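

Going by these compounds alone, the exchange of phenoxy for dimethylamino gives the first comparison here of compounds that differ in one place, and in this assay it amounts to a number 5 percentage points higher from compound 3 to compound 4 (within the scatter). At this position, para to a large group, a group with a six-membered aromatic ring of carbon only and one with no ring therefore cannot be told apart. Nothing available explains this result.

Going by these compounds, it remains open whether a carboxylic acid or a longer chain at this position would give a step beyond the scatter. The compounds shown also leave open how any of these groups would read at another concentration.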